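Working notes: chloro replacing hydrogen, compound 3 to compound 4

The source may report more compounds than this note shows. Statements on the series, on what has been measured and on what is new or still open speak of the compounds shown alone.

Measured so far:
compound 1 `Cc1nc(-c2ccc(Cl)cc2)sc1C(=O)CSc1nc(-c2ccc(Cl)c(Cl)c2)c(C#N)c(=O)[nH]1` — 36.5%
compound 2 `COc1ccc(-c2nc(SCC(=O)c3sc(-c4ccc(Cl)cc4)nc3C)[nH]c(=O)c2C#N)cc1OC` — 18.7%
compound 3 `Cc1nc(-c2ccccc2)sc1C(=O)CSc1nc(-c2ccc(Cl)cc2)c(C#N)c(=O)[nH]1` — 22.5%

In a functional assay on U-87MG ATCC cells for antiproliferative activity against U-87 MG (Homo sapiens), read by MTT assay, with a stated time of 48 h, tested at 100 uM (a higher number here means a weaker effect of the compound at the concentration tested, a lower number a stronger effect), compound 3 stands second highest of the three numbers; its value sits within the scatter of compound 2 and beyond the scatter below compound 1. Compound 4 `Cc1nc(-c2ccc(Cl)cc2)sc1C(=O)CSc1nc(-c2ccc(Cl)cc2)c(C#N)c(=O)[nH]1` is not yet measured. It differs from compound 3 by chloro in place of hydrogen on an aromatic carbon. Going by the values given here, the only measured step, a number 17.8 percentage points lower from compound 1 to compound 2 (beyond the scatter), concerns a different exchange and does not bear directly on this change. Among the compounds with values here, with no matching step to lean on, the expectation for compound 4 is a step of a number 4.5 percentage points higher from compound 3 to compound 4 (within the scatter) that need not exceed the scatter. Compound 4 is therefore estimated at 27%, with a range from 12% to 42%.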

Compound 4, a percentage reported as activity, at one concentration (the size of the read-out at that concentration, not a potency): 12.8%
Estimate against measurement, compound 4: 14.2 percentage points above; measured number inside the range.
By their numbers in this assay, from the lowest: compounds 4, 2 and 3 (each within the scatter of the next); then compound 1.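

In this assay, phenyl to 4-chlorophenyl gives a number 9.7 percentage points lower from compound 3 to compound 4 (within the scatter) and so cannot be told from scatter at this position. Going by these compounds alone, on the other aryl group, 4-chlorophenyl in place of 3,4-dimethoxyphenyl gives a number 5.9 percentage points lower from compound 2 to compound 4 (within the scatter) while hydrogen in place of chloro, from 3,4-dichlorophenyl to 4-chlorophenyl, gives a number 23.7 percentage points lower from compound 1 to compound 4 (beyond the scatter) as the only new step beyond the scatter. No measurement available here accounts for these steps.

On these data alone, what an amine or a carboxylic acid in place of chloro on this phenyl would give remains open.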